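Swapping a Sulfur Group for a Selenium Group in Cells

A few compounds are considered here, and "the series" means these few. Any claim that something is new, unique, unknown or untested is made for them only; others in the source may bear on it.

Measured compounds:
- compound 1, `C[Se]/C(=N\C(=O)c1cnc2ccccc2c1)NC(=O)c1cnc2ccccc2c1`, gives 60700 nM in a functional assay on MCF7 cells (Homo sapiens) for cytotoxicity, read by MTT assay, with a stated time of 72 h; on this read-out lower numbers stand for higher toxicity in this test and higher numbers for lower toxicity in this test
- compound 2, `CS/C(=N\C(=O)c1cnc2ccccc2c1)NC(=O)c1cnc2ccccc2c1`, gives > 100000 nM in this assay

For compound 2 the value is a limit of the test and not a number. Compound 2 therefore stands at the upper edge of what the test can report, the weaker end of the two results shown. Within the data shown here, the only measured step, an at least 1.6-fold higher number from compound 1 to compound 2 (0.21 log units; that floor lies within the scatter), exchanges the selenium-bearing group of compound 1 for the sulfur-bearing group of compound 2; its size is tied to the limit of > 100000 nM in this assay, at which 1 of the 2 values shown sits, so its true extent is not known.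

Compound 3, `O=C(/N=C(/NC(=O)c1cnc2ccccc2c1)[Se]Cc1ccccc1)c1cnc2ccccc2c1`, changes compound 2 at the same carbon: a group of 8 heavy atoms (7 carbon, 1 selenium; one six-membered aromatic ring of carbon only) in place of a group of 2 heavy atoms (1 carbon, 1 sulfur; no ring), on a carbon with a double bond to nitrogen. This brings selenium back, as in compound 1, but adds a benzyl-type group for which no comparison exists here. Among the measured compounds shown here, since the one known step from sulfur to selenium was small and within scatter, the expected step of an at least 2.0-fold lower number from compound 2 to compound 3 (0.30 log units; that floor lies within the scatter) is a modest lowering at most. Compound 3 is estimated at 50000 nM, within 15000 nM to 150000 nM.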

Compound 3, concentration lethal to 50% of the cells: > 100000 nM
Compound 3: a limit, no number; the forecaster's own chance of this, stated with the estimate: 35%; at least 2.0-fold (0.30 log units) between middle value and limit.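

In this assay compound 3 gives > 100000 nM, which is a limit of the test and not a number. Phenyl in place of hydrogen on a saturated chain carbon bound to a selenium atom gives an at least 1.6-fold higher number from compound 1 to compound 3 (0.21 log units; that floor lies within the scatter), so having selenium on the carbon with a double bond to nitrogen does not by itself bring a readable number in this test. The other step, which swaps the methylsulfanyl group for the selenium group with its aromatic ring, cannot be read, since both of its ends are limits: the limit of > 100000 nM in this assay, at which 2 of the 3 values shown sit.

Going by these compounds, how far compound 2 and compound 3 each lie past the limit stays unknown, so the true size of the steps that lead to them from compound 1 is open. Also open, on these data alone, is whether a longer chain on selenium, such as ethyl or butyl, or an amine on the same carbon would give a number in this assay.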